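Replacing a methoxy group with trifluoromethyl on a shared core

The source may hold more compounds than are shown below. What is called first, only, known or untested is meant among the compounds shown, and "the series" means these compounds.

Of the compounds shown here, two built on a shared core have been tested in a functional assay on Hep 3B2 cells (Homo sapiens) for antiproliferative activity, read by MTT assay, with a stated time of 24 h, tested at 3.7 ug/mL; a lower number here means a weaker effect, a higher number a stronger effect of the compound at the concentration tested. Compound 1 `Cc1c(C(=O)Nc2c(F)cc(-c3cccc(F)c3)cc2F)nc2ccc(C(F)(F)F)cc2c1O` gives 31.2% in this assay. Compound 2 `COc1ccc2nc(C(=O)Nc3c(F)cc(-c4cccc(F)c4)cc3F)c(C)c(C(=O)O)c2c1` gives 1.62% in this assay, the lowest of the two numbers; the nearest value, that of compound 1, lies well above it, a gap beyond the usual scatter. The two compounds differ in more than one place, so their values can only be set side by side, not traced to a single change.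

Compound 3 `Cc1c(C(=O)Nc2c(F)cc(-c3cccc(F)c3)cc2F)nc2ccc(C(F)(F)F)cc2c1C(=O)O` has not yet been measured in this assay. It differs from compound 2 in one place: trifluoromethyl in place of methoxy on an aromatic carbon. Compound 3 thereby carries the same trifluoromethyl group that compound 1 carries, while keeping the carboxylic acid of compound 2. For the measured compounds named here, no step of exactly this kind has been measured here, so the expectation rests only on the two values shown. The step of a number 10.4 percentage points higher from compound 2 to compound 3 (beyond the scatter) is expected to be a moderate rise, probably beyond the scatter. Compound 3 is estimated at 12% in this assay, between 0% and 32%.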

Compound 3, a percentage reported as inhibition, at one concentration (the size of the read-out at that concentration, not a potency): 21.3%
Compound 3: the middle estimate sits 9.3 percentage points below what was measured, within the range that was stated.
By their numbers in this assay, from the lowest: compound 2; then compounds 3 and 1 (each within the scatter of the next).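

For the compounds shown here, on this aromatic carbon, with the carboxylic acid held in place, trifluoromethyl in place of methoxy gives a number 19.7 percentage points higher from compound 2 to compound 3 (beyond the scatter) in this assay, the first single change here that can be read on its own. With trifluoromethyl held in place, carboxy in place of hydroxy on an aromatic carbon gives a number 9.9 percentage points lower from compound 1 to compound 3 (within the scatter), so this pair cannot be told apart, and of the two single changes only the swap of methoxy for trifluoromethyl moves the read-out beyond the usual scatter. Nothing shown here explains why either step turns out as it does.

On these data alone, only methoxy and trifluoromethyl can be compared directly on the first of these carbons, so it remains open whether a plain hydrogen, a chlorine atom or a nitrile there would give a similar rise from the level of compound 2. As far as these compounds go, it also remains open whether an amine or a methyl ester in the place that holds hydroxy or carboxy would stay level with these two groups or move the read-out clearly.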